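A few compounds are considered here, and "the series" means these few. Any claim that something is new, unique, unknown or untested is made for them only; others in the source may bear on it.

Compound 1 `C=C(CC)C(=O)c1ccc(OCC(=O)NC(CS)C(=O)OCC)c(Cl)c1Cl`: 4800 nM
Compound 2 `C=C(CC)C(=O)c1ccc(OCC(=O)Nc2ccc3cc(C(=O)O)ccc3c2)c(Cl)c1Cl`: 3700 nM
Compound 3 `C=C(CC)C(=O)c1ccc(OCC(=O)Nc2ccc3c(C)cc(=O)oc3c2)c(Cl)c1Cl`: 2800 nM

These three values come from a functional assay on CLL cells (Homo sapiens) for cytotoxicity, read by MTT assay, with a stated time of 48 h; a lower number here means that less compound is needed, a higher number that more compound is needed for the effect. Compound 1 gives the highest of the three numbers, but its gaps to compound 2 and to compound 3 both fall within the usual scatter, so the three compounds cannot be ranked against each other. The shared core is kept throughout; only the group on the amide-type nitrogen changes. Compound 4 `C=C(CC)C(=O)c1ccc(OCC(=O)NCCO)c(Cl)c1Cl` is not yet measured. It differs from compound 1 in one place: 2-hydroxyethyl in place of 1-(ethoxycarbonyl)-2-sulfanylethyl on an amide-type nitrogen. Among the measured compounds, quite different groups at this position leave the numbers close together, so only a small step from compound 1 to compound 4 is expected, estimated as a 1.3-fold higher number from compound 1 to compound 4 (0.10 log units; within the scatter), not beyond the scatter. For compound 4 the estimate is 6000 nM, expected to lie between 2500 nM and 14000 nM.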

Compound 4, half-maximal effective concentration: > 25000 nM
Compound 4: no number, only a limit (the forecaster's own chance of this, stated with the estimate: 10%); at least 4.1-fold (0.61 log units) between middle value and limit.
By their numbers in this assay, from the lowest: compounds 3, 2 and 1 (each within the scatter of the next). At a limit, above all of these: compound 4.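

The position on the amide-type nitrogen does matter: in this assay, 2-hydroxyethyl in place of 1-(ethoxycarbonyl)-2-sulfanylethyl brings an at least 5.2-fold higher number from compound 1 to compound 4 (0.71 log units; beyond the scatter), whereas compounds 1, 2 and 3 stayed within the scatter of each other. This step rests on a limit and not on a number: the limit of > 25000 nM in this assay, at which 1 of the 4 values shown sits.

The change removes the ethoxycarbonyl and the sulfanyl groups together, so the compounds shown do not separate their contributions. From the compounds shown here alone, a plain 2-sulfanylethyl chain, or a chain ending in an amine, remains open.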